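Ring size change at the chain amine of compound 3

The source may report more compounds than this note shows. Statements on the series, on what has been measured and on what is new or still open speak of the compounds shown alone.

Three compounds share one core and differ only in the amine at the end of the chain and in the anilide substituent. In a functional assay on U-937 cells (Homo sapiens) for cytotoxicity, read by WST assay, with a stated time of 72 h (on this read-out higher numbers stand for weaker inhibition and lower numbers for stronger inhibition), compound 1 `COc1cc2c(Nc3nc4ccc(C(=O)Nc5c(C)cccc5C)cc4s3)ncnc2cc1OCCCN1CCCCC1` gives 14700 nM, compound 2 `CCN(CC)CCCOc1cc2ncnc(Nc3nc4ccc(C(=O)Nc5c(C)cccc5Cl)cc4s3)c2cc1OC` gives 7300 nM, and compound 3 `COc1cc2c(Nc3nc4ccc(C(=O)Nc5c(C)cccc5Cl)cc4s3)ncnc2cc1OCCCN1CCCC1` gives 19900 nM. Compound 3 stands highest of the three numbers on this assay; its nearest neighbour is compound 1, within the scatter, and its furthest is compound 2, beyond it. Among the compounds with values here, the single step measured so far that touches the chain amine is a 2.7-fold higher number from compound 2 to compound 3 (0.44 log units; beyond the scatter), a modest rise.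

Compound 4 `COc1cc2c(Nc3nc4ccc(C(=O)Nc5c(C)cccc5Cl)cc4s3)ncnc2cc1OCCCN1CCCCC1` is not yet measured. It differs from compound 3 by piperidin-1-yl in place of pyrrolidin-1-yl on a saturated chain carbon, three bonds along the chain from an oxygen on an aromatic ring. Within the data shown here, no measured step reports exactly this change. Compound 1 carries the same piperidin-1-yl group on a different anilide, and its value and that of compound 3 lie within the scatter of each other, so no large shift can be read from them. Among the measured compounds shown here, the one measured step at this position is modest, and the entering and leaving groups are alike in counted donors and acceptors. Compound 4 is therefore expected to stay close to compound 3, with a 1.3-fold lower number from compound 3 to compound 4 (0.12 log units; within the scatter) as the estimated step, and an estimated value of 15000 nM between 7000 nM and 33000 nM.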

Compound 4, half-maximal inhibitory concentration: 8600 nM
Compound 4: the middle estimate sits 1.7-fold (0.24 log units) above what was measured, and the stated range covers the measured number.
By their numbers in this assay, from the lowest: compounds 2, 4, 1 and 3 (each within the scatter of the next, the first and the last beyond it).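

In this assay, the size of the saturated ring at the end of the chain turns out to matter modestly: piperidin-1-yl in place of pyrrolidin-1-yl gives a 2.3-fold lower number from compound 3 to compound 4 (0.36 log units; beyond the scatter) and so takes the value beyond the scatter. Piperidin-1-yl in place of diethylamino gives a 1.2-fold higher number from compound 2 to compound 4 (0.07 log units; within the scatter), which, read with a 2.7-fold higher number from compound 2 to compound 3 (0.44 log units; beyond the scatter), sets the pyrrolidin-1-yl compound apart from the other two amines on this anilide, while those two cannot be told apart. Within the data shown here, the same result gives the first direct reading of the anilide substituent, since chloro in place of methyl on an aromatic carbon gives a 1.7-fold lower number from compound 1 to compound 4 (0.23 log units; within the scatter), a change that cannot be told from repeat scatter in this one pair.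

Nothing given here explains why the five-membered ring stands apart from the six-membered ring and the open diethylamino group. Going by these compounds, it remains open how a larger ring such as azepan-1-yl, a ring with a second hetero atom such as morpholin-4-yl or 4-methylpiperazin-1-yl, or a shorter 2-(piperidin-1-yl)ethyl chain would compare with these amines.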